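Side-chain stereochemistry in a prostanoid ester series

The compounds below may be only part of what the source reports. "The series", "measured", "known", "first", "only" and "open" are said of these compounds alone.

Measured compounds:
compound 1 `CCCC[C@](C)(OC)[C@H](O)/C=C/C1[C@H](O)C[C@H](O)[C@@H]1C/C=C\CCCC(=O)OC`, 1.82 mg/kg
compound 2 `CCCC[C@](C)(OC)[C@H](O)/C=C/C1[C@H](O)CC(=O)[C@@H]1C/C=C\CCCC(=O)OC`, 0.479 mg/kg
compound 3 `CCCC[C@@](C)(OC)[C@H](O)/C=C/C1[C@H](O)CC(=O)[C@@H]1CCCCCCC(=O)OC`, 1.35 mg/kg

In a functional assay on the whole organism with Mus musculus as the target (on this read-out lower numbers stand for an effect already at smaller amounts and higher numbers for an effect only at larger amounts of compound), compound 1 gives the highest number of the three. Its nearest neighbour is compound 3 with 1.35 mg/kg, a gap that sits within the usual scatter, so no order between compound 1 and compound 3 is claimed. Compound 2 with 0.479 mg/kg lies furthest away, and that gap is beyond the scatter, so compound 2 acts at clearly smaller doses than compound 1.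

Compound 4 `CCCC[C@@](C)(OC)[C@@H](O)/C=C/C1[C@H](O)C[C@H](O)[C@@H]1C/C=C\CCCC(=O)OC` is the unmeasured member. Relative to compound 1 the change is the two compounds have the same atoms and bonds; at least one stereo element is drawn with a configuration in one of them and without one in the other: 2 of 8 stereo elements differ; a stereocentre at a saturated chain carbon is drawn S in compound 1 and R in compound 4; a stereocentre at a saturated chain carbon is drawn R in compound 1 and S in compound 4. Among the measured compounds shown here, no pair among the measured compounds isolates such an inversion, so there is no measured step to lean on. In this assay the two inverted centres are expected to shift the number moderately upward, that is towards an effect only at somewhat larger doses, a step of a 2.2-fold higher number from compound 1 to compound 4 (0.34 log units; beyond the scatter), with wide uncertainty in both directions. For compound 4 the estimate is 4 mg/kg, with a range from 1 mg/kg to 16 mg/kg.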

Compound 4, dose for half-maximal effect: > 4 mg/kg
Compound 4 was reported as a limit; the forecaster's own chance of this, stated with the estimate: 5%; the middle value sits exactly at the limit.
By their numbers in this assay, from the lowest: compound 2; then compounds 3 and 1 (each within the scatter of the next). At a limit, above all of these: compound 4.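

In this assay compound 4 gives > 4 mg/kg, which is a limit and not a number. Among the compounds shown here, with atoms and bonds unchanged, inverting the two stereocentres at saturated chain carbons gives an at least 2.1-fold higher number from compound 1 to compound 4 (0.34 log units; beyond the scatter), so configuration alone moves the dose read-out beyond the scatter, something no earlier pair could isolate. How far the step reaches is not fixed: the limit of > 4 mg/kg in this assay, at which 1 of the 4 values shown sits.

Which of the two centres carries the step stays open, and the comparison carries a further reservation: the fact that one of compounds 1 and 4 is drawn with a defined configuration and the other without, at the place where they differ Also open is whether the same dependence on configuration holds for a free carboxylic acid in place of the methyl ester, or for the compounds with a ring carbonyl such as compound 2.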